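Furan and methylpyrazole aryl ethers at the alpha-1D receptor

This account rests on a few compounds, and the source may have more. Where it says the series, first, only, none or still open, it means among the compounds named here.

Compound 1 `c1ccc(-c2cc[nH]n2)c(OCC2=NCCN2)c1`: < 100000 nM
Compound 2 `Cc1ccoc1-c1ccccc1OCC1=NCCN1`: < 100000 nM
Compound 3 `Cn1nccc1-c1ccccc1OCC1=NCCN1`: not yet measured

In a functional assay for activation of Alpha-1D adrenergic receptor (Homo sapiens), read by calcium flux (on this read-out lower numbers stand for an effect already at smaller amounts and higher numbers for an effect only at larger amounts of compound), compound 1 gives < 100000 nM, which is a limit of the assay and not a number. Compound 2 in this assay gives < 100000 nM, again a limit and not a number. The step that the two limits leave unreadable from compound 1 to compound 2 therefore cannot be read. Compound 2 thus stands at the limit of < 100000 nM in this assay, at which 2 of the 2 values shown sit.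

Compound 3 differs from compound 2 in one place: 1-methyl-1H-pyrazol-5-yl in place of 3-methylfuran-2-yl on an aromatic carbon. Among the measured compounds shown here, the sole measured step, from compound 1 to compound 2, bears on this change only in that it also exchanges one five-membered aromatic ring for another, and its size is not readable. For the measured compounds named here, no measured step shows how compound 3 should move in this assay. With both shown values sitting at the limit, compound 3 is expected most likely to be reported as a limit as well, and the estimated step that the limit leaves unreadable from compound 2 to compound 3 is taken as none beyond the scatter. Compound 3 is therefore estimated near 10000 nM, in the range 300 nM to 100000 nM.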

Compound 3, half-maximal effective concentration: < 100000 nM
Compound 3 ended at the assay's limit; the forecaster's own chance of this, stated with the estimate: 60%; the middle value is on the limit's open side.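

In this assay compound 3 gives < 100000 nM as well, a limit of the assay and not a number. Among the compounds shown here, no step among compound 1, compound 2 and compound 3 can be read, since all three sit at one limit: the limit of < 100000 nM in this assay, at which 3 of the 3 values shown sit. The compounds shown leave open how the 1H-pyrazol-3-yl, 3-methylfuran-2-yl and 1-methyl-1H-pyrazol-5-yl groups compare in actual numbers.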